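Thiophene ester series: pyridin-4-ylmethyl ester, protein kinase C zeta

A few compounds are considered here, and "the series" means these few. Any claim that something is new, unique, unknown or untested is made for them only; others in the source may bear on it.

Measured so far:
- compound 1, `COCC(C)OC(=O)c1c(-c2ccc(OC)c(OC)c2)csc1N`, 49% in an assay on isolated protein for inhibition of protein kinase C zeta type (Homo sapiens), with stated times of 1 h and 2.5 min, tested at 30 uM; a lower number here means less inhibition, a higher number more inhibition at the concentration tested (going by the name of the read-out)
- compound 2, `COc1ccc(-c2csc(N)c2C(=O)OCc2ccc(C#N)cc2)cc1OC`, 10%

Compound 2 stands lowest of the two numbers in this assay; its nearest neighbour is compound 1, and the step of a number 39 percentage points lower from compound 1 to compound 2 (beyond the scatter) is beyond the scatter. That step exchanges the whole group on the oxygen next to the carbonyl.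

Compound 3, `COc1ccc(-c2csc(N)c2C(=O)OCc2ccncc2)cc1OC`, differs from compound 2 by pyridin-4-yl in place of 4-cyanophenyl on a saturated chain carbon bound to an oxygen next to a carbonyl group. Among the measured compounds shown here, no measured step changes the ring at the end of the benzyl-type ester while keeping the rest; the step from compound 1 to compound 2 changes the entire ester group at once, so it only shows that this position can move the read-out strongly, not which way a pyridin-4-yl for 4-cyanophenyl swap goes. With compound 2 already low, the expectation for compound 3 is a step of a number 5 percentage points higher from compound 2 to compound 3 (within the scatter), within the scatter. Compound 3 is estimated at 15%, with a range of 0% to 40%.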

Compound 3, a percentage reported as inhibition, at one concentration (the size of the read-out at that concentration, not a potency): 53%
Compound 3: middle estimate off by 38 percentage points, on the low side; the whole stated range lies below it.
By their numbers in this assay, from the lowest: compound 2; then compounds 1 and 3 (each within the scatter of the next).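

With the rest of the molecule held constant, pyridin-4-yl in place of 4-cyanophenyl gives a number 43 percentage points higher from compound 2 to compound 3 (beyond the scatter) in this assay and so shows that the ring at the end of the ester can alone carry a large change in this read-out. The low number of compound 2 therefore does not extend to every ester with a ring on its methylene carbon: (pyridin-4-yl)methyl in place of 1-(methoxymethyl)ethyl gives a number 4 percentage points higher from compound 1 to compound 3 (within the scatter) and leaves these two quite different esters level. Nothing at hand explains the size of the step from the cyano-bearing ring to the pyridine ring.

As far as these compounds go, whether the low number of compound 2 follows the nitrile or the carbon-only ring stays open, and a plain benzyl ester would separate the two. Also open, from the compounds shown here alone, is how a 2-(pyridin-4-yl)ethyl ester or an amide in place of the ester would read.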